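A few compounds are considered here, and "the series" means these few. Any claim that something is new, unique, unknown or untested is made for them only; others in the source may bear on it.

Of the compounds shown here, three of one shared core have been measured in a functional assay on BT-549 cells (Homo sapiens) for inhibition, read by sulforhodamine B assay, with a stated time of 48 h; on this read-out higher numbers stand for weaker inhibition of growth and lower numbers for stronger inhibition of growth. Compound 1 `O=C(Nc1cccc(-n2cc(-c3ccncc3)c(-c3ccc(Cl)c(O)c3)n2)c1)Nc1cccc(C(F)(F)F)c1` gives 6510 nM, compound 2 `COc1cc(-c2nn(-c3cccc(NC(=O)Nc4cc(C(F)(F)F)cc(C(F)(F)F)c4)c3)cc2-c2ccncc2)ccc1Cl` gives 1210 nM, and compound 3 `COc1cc(-c2nn(-c3cccc(NC(=O)c4cccc(C(F)(F)F)c4)c3)cc2-c2ccncc2)ccc1Cl` gives 2870 nM. On these three numbers compound 3 stands second highest: compound 1 lies above it, beyond the scatter, and compound 2 lies below it, again beyond the scatter. Compounds 1 and 2 both carry a urea linker, while compound 3 carries a simple amide; compound 2 shares with compound 3 the methoxy and chloro substitution on the core.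

Compound 4 `COc1cc(-c2nn(-c3cccc(NC(=O)Nc4ccc(Cl)c(Cl)c4)c3)cc2-c2ccncc2)ccc1Cl` has not yet been measured in this assay. It differs from compound 3 in one place: (3,4-dichlorophenyl)amino in place of 3-(trifluoromethyl)phenyl on a carbonyl carbon. Compound 4 thus returns to the urea linker of compounds 1 and 2 while keeping the methoxy and chloro substitution of compound 2. Because compound 2, the closest urea on this core, gives 1210 nM, the number for compound 4 is expected to lie below that of compound 3, by a moderate step, although the scatter could absorb part of it. The expected step from compound 3 to compound 4 is a 1.9-fold lower number from compound 3 to compound 4 (0.28 log units; within the scatter). Compound 4 is therefore estimated at 1500 nM, with a range from 500 nM to 5000 nM.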

Compound 4, concentration for 50% growth inhibition: 1680 nM
Beside the measured number, compound 4's estimate is 1.1-fold (0.05 log units) below it, and the stated range covers the measured number.
By their numbers in this assay, from the lowest: compounds 2, 4 and 3 (each within the scatter of the next, the first and the last beyond it); then compound 1.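

In this assay, placing (3,4-dichlorophenyl)amino in place of 3-(trifluoromethyl)phenyl on a carbonyl carbon gives a 1.7-fold lower number from compound 3 to compound 4 (0.23 log units; within the scatter). Within the data shown here, this is the first pair on the shared core that differs in one place, and it shows that a (3-(trifluoromethyl)phenyl)carbonyl can give way to a (3,4-dichlorophenyl)carbamoyl, with one hydrogen-bond donor entering and the trifluoromethyl replaced by two chlorines, without the number moving beyond the usual scatter. Nothing at hand offers an account of why the two compounds read alike.

The linker and the ring substituents change together in this single step, so the compounds shown do not separate the contribution of the urea from that of the chlorines, and neither a urea carrying 3-(trifluoromethyl)phenyl nor an amide carrying 3,4-dichlorophenyl appears on this core with the same methoxy and chloro substitution. Going by these compounds, it also remains open whether a morpholine, a carboxylic acid or a longer alkyl chain on this carbonyl carbon would keep the number in the same range.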